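The source may report more compounds than this note shows. Statements on the series, on what has been measured and on what is new or still open speak of the compounds shown alone.

In a functional assay on MDA-MB-435 cells (Homo sapiens) for cytotoxicity, read by sulforhodamine B assay, with a stated time of 48 h, tested at 1 uM (a lower number here means a stronger effect, a higher number a weaker effect of the compound at the concentration tested), compound 1 `COc1ccc(-c2cc(/C=C/C(=O)c3ccc(N)cc3)[nH]n2)cc1` gives 85%. Compound 2 `COc1cc(-c2cc(/C=C/C(=O)c3ccc(Cl)c(Cl)c3)[nH]n2)cc(OC)c1OC` gives 90%, and compound 3 `COc1ccc(C(=O)/C=C/c2cc(-c3cc(OC)c(OC)c(OC)c3)n[nH]2)cc1` gives 92%. Among these three, the number for compound 1 is the smallest, but its gaps to compound 2 and to compound 3 both fall within the scatter of this kind of measurement, so the three compounds cannot be told apart on these figures. Among the compounds with values here, the only single-point comparison among the measured compounds, a number 2 percentage points higher from compound 2 to compound 3 (within the scatter), concerns 4-methoxyphenyl in place of 3,4-dichlorophenyl on a carbonyl carbon and left the read-out essentially unchanged.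

Compound 4 `COc1ccc(-c2cc(/C=C/C(=O)c3ccc(N)cc3)[nH]n2)cc1OC` differs from compound 1 in another place: methoxy in place of hydrogen on an aromatic carbon. Within the data shown here, no measured pair isolates this change, so there is no direct guide to its effect. Among the measured compounds shown here, what the measured compounds do show is that all three values sit close together and that the one measured step stayed within the scatter. On that basis, the expected step of a number 2 percentage points higher from compound 1 to compound 4 (within the scatter) is none beyond the scatter. Compound 4 is therefore estimated at 87%, within a range from 72% to 100%.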

Compound 4, a percentage reported as activity, at one concentration (the size of the read-out at that concentration, not a potency): 94%
For compound 4 the middle estimate is 7 percentage points below the measured one, and the stated range covers the measured number.
By their numbers in this assay, from the lowest: compounds 1, 2, 3 and 4 (each within the scatter of the next).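

Within the data shown here, this is the first direct look at this position on the ring of compound 1: putting methoxy in place of hydrogen, ortho to a methoxy group and meta to a large group, gives a number 9 percentage points higher from compound 1 to compound 4 (within the scatter) in this assay. The step therefore does not separate the two compounds, so a second methoxy group can stand at this aromatic carbon without a read-out that can be told apart from that of compound 1. Among these compounds, with only this one pair, that finding holds for this change on this core and cannot be extended to other compounds, and no measured information on the compounds explains the result.

The compounds shown leave open whether a different group at this same aromatic carbon, such as a hydroxyl group, a fluorine atom or a longer ethoxy chain, would move the read-out beyond the scatter. They also leave open whether compound 1 and compound 4 would still look alike at other concentrations, since a read-out at one concentration is not a potency.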